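This account rests on a few compounds, and the source may have more. Where it says the series, first, only, none or still open, it means among the compounds named here.

Measured compounds in a functional assay (aorta) for antagonist activity, with Oryctolagus cuniculus as the target; on this read-out lower numbers stand for stronger inhibition and higher numbers for weaker inhibition:
- compound 1 `CCCCc1ccc(CNC(C)=O)c(=O)n1Cc1ccc(-c2ccccc2-c2nn[nH]n2)cc1` gives 3 nM
- compound 2 `CCCCc1ccc(CN(Cc2ccccc2)C(C)=O)c(=O)n1Cc1ccc(-c2ccccc2-c2nn[nH]n2)cc1` gives 1 nM
- compound 3 `CCCCc1ccc(CN(C)S(=O)(=O)c2ccccc2)c(=O)n1Cc1ccc(-c2ccccc2-c2nn[nH]n2)cc1` gives 2 nM

Compound 3 sits second highest of the three numbers; against compound 1 the gap is within the scatter, against compound 2 likewise within the scatter, so no order among the three is secure.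

The step to compound 4 `CCCCc1ccc(CN(C(C)C)S(C)(=O)=O)c(=O)n1Cc1ccc(-c2ccccc2-c2nn[nH]n2)cc1` changes the same position worked in the two measured steps leading to compound 3: isopropyl(methylsulfonyl)amino in place of methyl(phenylsulfonyl)amino on a saturated chain carbon bound to an aromatic carbon.

Within the data shown here, the steps that bear on it are a 1.5-fold lower number from compound 1 to compound 3 (0.18 log units; within the scatter) and a 2.0-fold higher number from compound 2 to compound 3 (0.30 log units; within the scatter), both within the scatter, whereas the only step beyond the scatter, a 3.0-fold lower number from compound 1 to compound 2 (0.48 log units; beyond the scatter), concerns a different exchange on the amide-type nitrogen. Every change tried so far at this position has left the number in a narrow window. Among the measured compounds shown here, no measured compound carries isopropyl(methylsulfonyl)amino, so the new group is untested.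

For compound 4 the step of a 1.5-fold higher number from compound 3 to compound 4 (0.18 log units; within the scatter) is expected, that is no change beyond the scatter. Compound 4 is accordingly estimated at 3 nM, with a range from 1 nM to 10 nM in this assay.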

Compound 4, half-maximal inhibitory concentration: 0.9 nM
Compound 4: middle estimate off by 3.3-fold (0.52 log units), on the high side; the measured number lies below the stated range.
By their numbers in this assay, from the lowest: compounds 4, 2, 3 and 1 (each within the scatter of the next, the first and the last beyond it).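

In this assay, the position on a saturated chain carbon bound to an aromatic carbon now shows a change among the sulfonyl groups that lies beyond the scatter (a 2.2-fold lower number from compound 3 to compound 4 (0.35 log units; beyond the scatter)), so the number here is less fixed than the first three compounds suggested. The one six-membered aromatic ring of methyl(phenylsulfonyl)amino is not required for a low number; the step from the acetamido compound is also beyond the scatter (a 3.3-fold lower number from compound 1 to compound 4 (0.52 log units; beyond the scatter)), whereas isopropyl(methylsulfonyl)amino and acetyl(benzyl)amino cannot be told apart (a 1.1-fold lower number from compound 2 to compound 4 (0.05 log units; within the scatter)). Nothing on hand explains the step from compound 3 to compound 4.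

From the compounds shown here alone, the isopropyl and the methyl on sulfonyl change together in this step, and the share of each stays open. Also open, going by these compounds, is how tert-butyl or cyclopropyl on the nitrogen, or an amine or a carboxylic acid in place of the whole group, would read.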